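This account rests on a few compounds, and the source may have more. Where it says the series, first, only, none or still open, it means among the compounds named here.

The series shares one core, varied at the amide on the aniline. Compound 1 `CN(C)c1ccc(C(=O)Nc2cccc(NC(=O)COc3ccc4c(c3)NC(=O)CC4)c2)cc1` and compound 2 `Cc1coc2cc(OCC(=O)Nc3cccc(NC(=O)c4ccc(N(C)C)cc4)c3)ccc2c1=O` carry an aromatic amide there; compound 3 `CC(=O)Nc1cccc(NC(=O)COc2ccc3c(=O)ccoc3c2)c1` carries an acetamide. In an assay on isolated protein for inhibition of Rho-associated protein kinase 1 (Homo sapiens), read by scintillation counting, radiometric assay and 33P incorporation, with a stated time of 40 min, in the presence of a further agent that is not named here (a lower number here means a stronger inhibitor, a higher number a weaker inhibitor), compound 1 gives > 10000 nM, a limit of the assay. Compound 2 likewise returns only a limit, > 10000 nM. Among the compounds with values here, compound 3 gives 2500 nM, the single number in the set, while the other two values rest at the limit of > 10000 nM in this assay, at which 2 of the 3 values shown sit. Compound 4 `COc1ccc(C(=O)Nc2cccc(NC(=O)COc3ccc4c(=O)ccoc4c3)c2)cc1`, not yet measured, differs from compound 3 by 4-methoxyphenyl in place of methyl on a carbonyl carbon. Within the data shown here, no measured pair covers this change. The two aromatic amides, compound 1 and compound 2, both sit at the limit. The step of a 3.2-fold higher number from compound 3 to compound 4 (0.51 log units; beyond the scatter) is therefore expected to run toward weaker inhibition, beyond the scatter. Compound 4 is estimated at 8000 nM, within 2000 nM to 30000 nM, with a real chance of only a limit.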

Compound 4, half-maximal inhibitory concentration: 18 nM
The estimate for compound 4 lay 440-fold (2.65 log units) above the measured number; measured number below the stated range.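

In this assay, 4-methoxyphenyl in place of methyl on a carbonyl carbon gives a 140-fold lower number from compound 3 to compound 4 (2.14 log units; beyond the scatter), so this position accepts an aromatic amide with far stronger inhibition than the acetamide. Compound 1 and compound 2 differ from compound 4 in more than one place, so their limits cannot be read against this gain. Nothing shown gives a cause for the step. Open, going by these compounds, is how much of the step belongs to the methoxy group and how much to the ring. An unsubstituted phenyl or a 4-aminophenyl at this carbonyl carbon would separate the two.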